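Sulfonyl substituent variation in the trifluoromethyl hydroxy amide series

The compounds below may be only part of what the source reports. "The series", "measured", "known", "first", "only" and "open" are said of these compounds alone.

Measured compounds:
compound 1 `CC(O)(C(=O)Nc1ccc(S(=O)(=O)c2ccccc2C#N)cc1)C(F)(F)F` — in a functional assay (Cavia porcellus) with sulfonylurea receptors; K-ATP channels (Homo sapiens) as the target (on this read-out higher numbers stand for weaker inhibition and lower numbers for stronger inhibition), compound 1 gives 1100 nM
compound 2 `Cc1ccc(S(=O)(=O)c2ccc(NC(=O)C(C)(O)C(F)(F)F)cc2)cc1` — in this assay compound 2 gives only a limit, > 30000 nM
compound 3 `CN(c1ccccc1)S(=O)(=O)c1ccc(NC(=O)C(C)(O)C(F)(F)F)cc1` — in this assay compound 3 gives 2000 nM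

Compound 3 stands highest of the two numbers shown, with compound 1 nearest; the step of a 1.8-fold higher number from compound 1 to compound 3 (0.26 log units; within the scatter) is within the scatter. Compound 2 sits at the limit of the assay (the limit of > 30000 nM in this assay, at which 1 of the 3 values shown sits). Both steps to compound 2 are large: an at least 27-fold higher number from compound 1 to compound 2 (1.43 log units; beyond the scatter) and an at least 15-fold lower number from compound 2 to compound 3 (1.17 log units; beyond the scatter). The group on the sulfonyl sulfur thus moves the number across a wide span, while 2-cyanophenyl and methyl(phenyl)amino give much the same result.

Compound 4 `CC(O)(C(=O)Nc1ccc(S(=O)(=O)c2nccs2)cc1)C(F)(F)F` differs from compound 3 by 1,3-thiazol-2-yl in place of methyl(phenyl)amino on a sulfonyl sulfur. Within the data shown here, no measured step exchanges a group on the sulfonyl sulfur for a five-membered heteroaryl, so the measured steps bear on it only indirectly: they set the range in which such changes have fallen, from the scatter-sized step to compound 1 to the large step to compound 2. The step from compound 3 to compound 4 is expected to be modest, a 1.5-fold higher number from compound 3 to compound 4 (0.18 log units; within the scatter). Compound 4 is estimated at 3000 nM, with a range of 800 nM to 15000 nM.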

Compound 4, half-maximal inhibitory concentration: 1400 nM
Beside the measured number, compound 4's estimate is 2.1-fold (0.33 log units) above it; measured number inside the range.
By their numbers in this assay, from the lowest: compounds 1, 4 and 3 (each within the scatter of the next). At a limit, above all of these: compound 2.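

In this assay, a five-membered heteroaryl on the sulfonyl sulfur stays within the scatter of both closest comparators, with a 1.4-fold lower number from compound 3 to compound 4 (0.15 log units; within the scatter) and a 1.3-fold higher number from compound 1 to compound 4 (0.10 log units; within the scatter), so 1,3-thiazol-2-yl sits with methyl(phenyl)amino and 2-cyanophenyl even though its ring and its count of hydrogen-bond acceptors differ from those of methyl(phenyl)amino. Among these compounds, the gap to the remaining group stays large, with an at least 21-fold lower number from compound 2 to compound 4 (1.33 log units; beyond the scatter), which leaves 4-methylphenyl as the only one of the four groups set apart. The value of compound 2 is a limit of the assay and not a number: the limit of > 30000 nM in this assay, at which 1 of the 4 values shown sits.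

The compounds shown do not tell what sets 4-methylphenyl apart from the other three groups. A plain phenyl or a 4-cyanophenyl on the sulfonyl sulfur would bear on whether the methyl or the nitrile decides the outcome.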